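The source may report more compounds than this note shows. Statements on the series, on what has been measured and on what is new or still open speak of the compounds shown alone.

Measured compounds so far:

- compound 1, `N#Cc1ccc(-c2cnc3[nH]cc(-c4nnc(-c5ccc(Cl)cc5)o4)c(=O)c3c2)cc1`: in a functional assay on HCT-116 cells (Homo sapiens) for positive allosteric modulation, read by MTT assay, with stated times of 24 h and 48 h, tested at 2.5 uM (on this read-out lower numbers stand for less inhibition of growth and higher numbers for more inhibition of growth at the one concentration tested), compound 1 gives 35.4%
- compound 2, `O=c1c(-c2nnc(-c3ccc(F)cc3)o2)c[nH]c2ncc(-c3ccncc3)cc12`: in this assay compound 2 gives 19.6%
- compound 3, `Cc1ccc(-c2nnc(-c3c[nH]c4ncc(-c5ccc(S(C)(=O)=O)cc5)cc4c3=O)o2)cc1`: in this assay compound 3 gives 54.8%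

Compound 3 stands highest of the three numbers in this assay. The nearest is compound 1, whose number is lower by a margin beyond the scatter; the furthest is compound 2, lower still and also beyond the scatter. Among the compounds with values here, no two of the measured compounds differ in one place only, so no single step between measured compounds can be read off, and no pattern for any one change is available.

Compound 4 is `CS(=O)(=O)c1ccc(-c2cnc3[nH]cc(-c4nnc(-c5ccccn5)o4)c(=O)c3c2)cc1`. It differs from compound 3 by pyridin-2-yl in place of 4-methylphenyl on an aromatic carbon. The change sits on the five-membered aromatic ring with two nitrogen and one oxygen, leaving the rest of compound 3 untouched.

Within the data shown here, with no comparable step among the measured compounds, the expectation for the step from compound 3 to compound 4 in this assay rests on the value of compound 3 alone and on the fact that the three measured numbers spread widely. A moderate drop is expected, a number 12.8 percentage points lower from compound 3 to compound 4 (beyond the scatter), though a change within the scatter cannot be ruled out. Compound 4 is estimated at 42%, with a range from 22% to 62%.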

Compound 4, percent growth inhibition at one concentration: 34.3%
Estimate against measurement, compound 4: 7.7 percentage points above; low and high end bracket the measured number.
By their numbers in this assay, from the lowest: compound 2; then compounds 4 and 1 (each within the scatter of the next); then compound 3.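

Working notes: the exchange of 4-methylphenyl for pyridin-2-yl gives the first step in the series that can be read at a single place. In this assay, the step is a number 20.5 percentage points lower from compound 3 to compound 4 (beyond the scatter), so what sits on this aromatic carbon of the five-membered aromatic ring with 2 nitrogen and 1 oxygen matters to growth inhibition at the one concentration tested, at least with the methylsulfonylphenyl group of compound 3 and compound 4 held constant. No measurement bears on why the number falls with this change.

This one step changes the ring atoms and removes the methyl group together, so an unsubstituted phenyl group on the same carbon would be needed to separate the two changes, and the shown compounds include none. As far as these compounds go, the other measured compounds differ from compound 3 and compound 4 in more than one place, so their steps cannot be read, and it remains open whether this step would hold with the 4-cyanophenyl or pyridine group found on the other side of the core of compound 1 and compound 2.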